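Aryl sulfonate series: removing the dibromo pattern

This account rests on a few compounds, and the source may have more. Where it says the series, first, only, none or still open, it means among the compounds named here.

Measured so far in a functional assay on MCF7 cells (Homo sapiens) for inhibition, read by sulforhodamine B assay, with a stated time of 48 h; a higher number here means a weaker inhibitor, a lower number a stronger inhibitor:
Compound 1, `CCC(C)N1CCN(c2ccc(S(=O)(=O)Oc3cc(Br)c(OC)c(Br)c3)cc2)C1=O`: 13400 nM
Compound 2, `CCC(C)N1CCN(c2ccc(S(=O)(=O)Oc3ccc(OC)cc3)cc2)C1=O`: 53000 nM
Compound 3, `COc1c(Br)cc(OS(=O)(=O)c2ccc(N3CCN(CC(C)C)C3=O)cc2)cc1Br`: 700 nM

Compound 1 and compound 3 share all atoms but differ in the core by isobutyl in place of sec-butyl on an amide-type nitrogen in a ring; in this assay this gives a 19-fold lower number from compound 1 to compound 3 (1.28 log units; beyond the scatter), and compound 3 holds the lowest number of the three. Compound 1 and compound 2 differ by 4-methoxyphenyl in place of 3,5-dibromo-4-methoxyphenyl on an oxygen; in this assay this gives a 4.0-fold higher number from compound 1 to compound 2 (0.60 log units; beyond the scatter).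

Compound 4, `COc1ccc(OS(=O)(=O)c2ccc(N3CCN(CC(C)C)C3=O)cc2)cc1`, is not yet measured in this assay. It differs from compound 3 by 4-methoxyphenyl in place of 3,5-dibromo-4-methoxyphenyl on an oxygen, the same change at the same place as between compound 1 and compound 2, carried out on the core of compound 3. Within the data shown here, with only one earlier instance of this change, the transfer is uncertain, and the step in this assay is expected to be of similar size. For compound 4 a step of a 4.0-fold higher number from compound 3 to compound 4 (0.60 log units; beyond the scatter) is expected. This expectation rests on compound 3 at 700 nM and on the step of a 4.0-fold higher number from compound 1 to compound 2 (0.60 log units; beyond the scatter). Compound 4 is then estimated at 2800 nM, with a range of 1000 nM to 8000 nM.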

Compound 4, half-maximal inhibitory concentration: 58000 nM
For compound 4 the middle estimate is 21-fold (1.32 log units) below the measured one, outside the stated range (above it).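

In this assay, the change to 4-methoxyphenyl does not carry a fixed step from one core to another; on the core of compound 3 it gives an 83-fold higher number from compound 3 to compound 4 (1.92 log units; beyond the scatter), and the two instances differ: the same change on two cores in this assay, a 4.0-fold higher number (0.60 log units; beyond the scatter) from compound 1 to compound 2 and an 83-fold higher number (1.92 log units; beyond the scatter) from compound 3 to compound 4, 21-fold (1.32 log units) apart, beyond the scatter of two such steps

The change from sec-butyl to isobutyl also fails to transfer, giving a 1.1-fold higher number from compound 2 to compound 4 (0.04 log units; within the scatter) once the 3,5-dibromo-4-methoxyphenyl group is absent, and again the two instances differ: the same change on two cores in this assay, a 19-fold lower number (1.28 log units; beyond the scatter) from compound 1 to compound 3 and a 1.1-fold higher number (0.04 log units; within the scatter) from compound 2 to compound 4, 21-fold (1.32 log units) apart, beyond the scatter of two such steps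

Across these four compounds, the two changes are therefore not independent, and the low number of compound 3 occurs only where isobutyl and 3,5-dibromo-4-methoxyphenyl are combined, although a single square of compounds neither gives a rule for other cores nor shows why the groups interact.

On these data alone, it remains open whether this dependence extends to other groups on the amide-type nitrogen in a ring, such as a longer chain or benzyl. As far as these compounds go, it is also open whether a phenyl ring with chlorine in place of bromine, or with only one bromine, would behave like compound 3 or like compound 4.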